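Removing one chain fluorine: compound 2 to compound 3

The source may report more compounds than this note shows. Statements on the series, on what has been measured and on what is new or still open speak of the compounds shown alone.

Of the compounds shown here, two have been measured in an assay on CHO-K1 cells for inhibition of 11-beta-hydroxysteroid dehydrogenase type 2 (Homo sapiens), read by scintillation proximity assay; a higher number here means a weaker inhibitor, a lower number a stronger inhibitor. Compound 1, `CCS(=O)(=O)CCC12CCC(c3nnc(-c4ccccc4C)n3C)(CC1)CC2`, gives in this assay > 4000 nM, which is a limit of the assay and not a number. Compound 2, `Cn1c(-c2ccccc2C(F)(F)F)nnc1C12CCC(CCCC(C)(F)F)(CC1)CC2`, gives in this assay > 4000 nM, again a limit rather than a number. Going by the values given here, compound 2 therefore stands at the limit of > 4000 nM in this assay, at which 2 of the 2 values shown sit, alongside compound 1; the two values do not separate the compounds, and no step between measured compounds can be drawn from them.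

Compound 3, `CC(F)CCCC12CCC(c3nnc(-c4ccccc4C(F)(F)F)n3C)(CC1)CC2`, has not been measured. It differs from compound 2 by hydrogen in place of fluoro on a saturated chain carbon bound to a fluorine atom and two saturated chain carbons. Among the compounds with values here, no measured step covers a change of this kind, so nothing here supports expecting a shift beyond the scatter in either direction in this assay. The expected step from compound 2 to compound 3 is a step that the limit leaves unreadable from compound 2 to compound 3, essentially none beyond the scatter. Compound 3 is accordingly expected near 6000 nM, within a range from 2000 nM to 20000 nM, and most likely the assay will again report only a limit.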

Compound 3, half-maximal inhibitory concentration: 1300 nM
Compound 3: middle estimate off by 4.6-fold (0.66 log units), on the high side, and the stated range ends above it.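

In this assay, going by these compounds alone, hydrogen in place of fluoro on a saturated chain carbon bound to a fluorine atom and two saturated chain carbons gives an at least 3.0-fold lower number from compound 2 to compound 3 (0.48 log units; beyond the scatter), a step beyond the scatter, so this chain position responds to the exchange of one fluorine atom for hydrogen, and compound 3 gives 1300 nM, the only value so far that is a number. Compound 2 gives > 4000 nM, which is a limit of the assay and not a number. The step is therefore a minimum, and its full size stays unknown: the limit of > 4000 nM in this assay, at which 2 of the 3 values shown sit.

Open, as far as these compounds go, is whether the chain with no fluorine at this carbon, a hydroxyl group in the same place or a longer chain would give a lower or a higher number than compound 3 in this assay. Also open, from the compounds shown here alone, is whether the same exchange gives a step of similar size when methyl stands in place of trifluoromethyl on the core of compound 3.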